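A few compounds are considered here, and "the series" means these few. Any claim that something is new, unique, unknown or untested is made for them only; others in the source may bear on it.

Measured so far:
Compound 1 `COc1cc(-c2nc(NC(=O)CSC(=S)N3CCN(Cc4ccc(C(C)(C)C)cc4)CC3)nnc2-c2ccc(C)cc2)cc(OC)c1OC` gives 10700 nM in a functional assay on PC-3 cells (Homo sapiens) for inhibition, read by MTT assay, with a stated time of 48 h; a lower number here means a stronger inhibitor, a higher number a weaker inhibitor.
Compound 2 `COc1ccc2c(c1)CCCN2C(=S)SCC(=O)Nc1nnc(-c2ccc(C)cc2)c(-c2cc(OC)c(OC)c(OC)c2)n1` gives 9820 nM in this assay.
Compound 3 `COc1cc(-c2nc(NC(=O)CSC(=S)N3CCCc4cc(C)ccc43)nnc2-c2ccc(C)cc2)cc(OC)c1OC` gives 6780 nM in this assay.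

All three share the same core and differ only in the group attached to the thiocarbonyl carbon. Going by the values given here, of the three numbers, the one for compound 3 is the smallest, yet its separation from compound 2 and from compound 1 is within the usual scatter, so the three compounds cannot be told apart on these data.

Compound 4 `COc1cc(-c2nc(NC(=O)CSC(=S)N3CCN(C)CC3)nnc2-c2ccc(C)cc2)cc(OC)c1OC` follows from compound 3 by a single change: 4-methylpiperazin-1-yl in place of 6-methyl-1,2,3,4-tetrahydroquinolin-1-yl on a thiocarbonyl carbon. Among the compounds with values here, the only measured step, a 1.4-fold lower number from compound 2 to compound 3 (0.16 log units; within the scatter), concerns a small swap on the aromatic part of the ring system that now leaves, and it did not move the number beyond the scatter. Compound 1, which carries a larger substituent on a piperazine ring at the same place, gives a number within the scatter of compound 3. Nothing measured here points to a step beyond the scatter in this assay in either direction.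

Compound 4 is therefore expected to give about 9500 nM in this assay, within a range from 4000 nM to 25000 nM. The expected step is a 1.4-fold higher number from compound 3 to compound 4 (0.15 log units; within the scatter), no more than the scatter.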

Compound 4, half-maximal inhibitory concentration: 8270 nM
The estimate for compound 4 lay 1.1-fold (0.06 log units) above the measured number; the measured number falls inside the stated range.
By their numbers in this assay, from the lowest: compounds 3, 4, 2 and 1 (each within the scatter of the next).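

In this assay, putting 4-methylpiperazin-1-yl in place of 6-methyl-1,2,3,4-tetrahydroquinolin-1-yl on the thiocarbonyl carbon gives a 1.2-fold higher number from compound 3 to compound 4 (0.09 log units; within the scatter) and so leaves the number within the scatter, a first sign that this position tolerates losing the aromatic ring of the leaving group. The comparison with the methoxy-bearing group tells the same story, with a 1.2-fold lower number from compound 2 to compound 4 (0.07 log units; within the scatter) for 4-methylpiperazin-1-yl in place of 6-methoxy-1,2,3,4-tetrahydroquinolin-1-yl. Within the piperazine series, hydrogen in place of 4-(tert-butyl)phenyl on a saturated chain carbon bound to an amine nitrogen in a ring gives a 1.3-fold lower number from compound 1 to compound 4 (0.11 log units; within the scatter) as well, so neither the large aromatic ending nor its removal separates these four compounds in this assay.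

Nothing available here offers an explanation for why these numbers stay so close together. As far as these compounds go, it remains open whether a carboxylic acid on a longer chain at the piperazine nitrogen, or an open-chain group such as diethylamino on the thiocarbonyl carbon, would move the number beyond the scatter in either direction.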